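Replacing tert-butoxy with methyl on a carbonyl carbon

This account rests on a few compounds, and the source may have more. Where it says the series, first, only, none or still open, it means among the compounds named here.

Measured in a functional assay for inhibition, with Rattus norvegicus as the target; a higher number here means that more compound is needed for the effect, a lower number that less compound is needed:
- Compound 1 `CC[C@H](CC1CCCCC1)NCc1ccc(C(=O)N[C@@H](CCSC)C(=O)O)c(-c2ccccc2C)c1`: > 1000 nM (a limit)
- Compound 2 `CSCC[C@H](NC(=O)c1ccc(CN(CCC2CCCCC2)C(=O)OC(C)(C)C)cc1-c1ccccc1C)C(=O)O`: 160 nM

Going by the values given here, compound 2, at 160 nM, holds the only actual number in this small set. Compound 1 is reported at > 1000 nM, which is a limit of this assay and not a number. The next compound to be tested is compound 3 `CSCC[C@H](NC(=O)c1ccc(CN(CCC2CCCCC2)C(C)=O)cc1-c1ccccc1C)C(=O)O`, which keeps the rest of compound 2 and carries methyl in place of tert-butoxy on a carbonyl carbon. The same difference can be read as tert-butoxycarbonyl to acetyl. Among the compounds with values here, no measured step shows what this exchange does, so the expectation rests only on compound 2 at 160 nM and on the size of the change. A move towards a higher number is expected, with the estimated size being a 2.5-fold higher number from compound 2 to compound 3 (0.40 log units; beyond the scatter), though the uncertainty is wide and a result within the usual scatter remains possible. For compound 3 the expected value in this assay is 400 nM, with an estimated range of 100 nM to 1600 nM.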

Compound 3, half-maximal effective concentration: > 1000 nM
Compound 3 ended at the assay's limit (the forecaster's own chance of this, stated with the estimate: 25%); middle value at least 2.5-fold (0.39 log units) from the limit.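

In this assay, going by these compounds alone, the exchange of tert-butoxy for methyl on a carbonyl carbon whose other neighbour is an amide-type nitrogen gives the first readable step at this position: an at least 6.2-fold higher number from compound 2 to compound 3 (0.79 log units; beyond the scatter). This shows that the position is not indifferent to the change, since tert-butoxycarbonyl to acetyl alone, with the rest of compound 2 kept, moves the result beyond the usual scatter. The full size of the step stays unknown because compound 3 ended at a limit and not at a number: the limit of > 1000 nM in this assay, at which 2 of the 3 values shown sit.

Compound 1 and compound 3 are both limits, so the step between them cannot be read, and the shown compounds do not tell how far compound 3 lies past its limit. Also open, going by these compounds, is whether a group such as methoxy, isopropoxy or tert-butylamino on the same carbonyl carbon would give a value nearer to that of compound 2 or one at the limit, and so whether tert-butoxy itself or some feature shared with such groups goes with the measurable value.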